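Moving the hydroxyl around the phenyl ketone ring

The source may hold more compounds than are shown below. What is called first, only, known or untested is meant among the compounds shown, and "the series" means these compounds.

Compound 1 `COc1ccccc1N1CCN(CCCCCC(=O)c2cccc(O)c2)CC1`: 26.8 nM
Compound 2 `COc1ccccc1N1CCN(CCCCC(=O)c2ccccc2O)CC1`: 16.4 nM

In an assay on isolated protein for binding affinity to 5-hydroxytryptamine receptor 7 (Rattus norvegicus) (on this read-out higher numbers stand for weaker inhibition and lower numbers for stronger inhibition), compound 1 gives 26.8 nM and compound 2 gives 16.4 nM; the two numbers lie within the scatter of each other, so compound 1 is neither stronger nor weaker than compound 2 on this evidence. Compound 3 `COc1ccccc1N1CCN(CCCCCC(=O)c2ccc(O)cc2)CC1` differs from compound 1 by 4-hydroxyphenyl in place of 3-hydroxyphenyl on a carbonyl carbon. Going by the values given here, no measured pair shows this particular change, so the expected step from compound 1 to compound 3 in this assay is an estimate at best: a modest shift, if any, toward a higher number, a 1.5-fold higher number from compound 1 to compound 3 (0.17 log units; within the scatter). Compound 3 is thus expected to give about 40 nM, with a range from 12 nM to 130 nM.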

Compound 3, inhibition constant: 23.7 nM
Compound 3: middle estimate off by 1.7-fold (0.23 log units), on the high side; the measured number falls inside the stated range.
By their numbers in this assay, from the lowest: compounds 2, 3 and 1 (each within the scatter of the next).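

In this assay, putting 4-hydroxyphenyl in place of 3-hydroxyphenyl on a carbonyl carbon gives a 1.1-fold lower number from compound 1 to compound 3 (0.05 log units; within the scatter), so these two placements of the hydroxyl cannot be told apart on this chain. The earlier pair could not show this, since compound 1 and compound 2 differ in more than one place. No measurement shown here offers an explanation for this result. Going by these compounds, whether the same holds on a shorter or longer chain remains open. So does the outcome of replacing the hydroxyl with an amine or a carboxylic acid.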